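Stability Of A Double Ester Prodrug And Its Half-Ester

The source may hold more compounds than are shown below. What is called first, only, known or untested is meant among the compounds shown, and "the series" means these compounds.

The account follows two compounds sharing one core. Compound 1 `CC(C)C(=O)OCOC(=O)C1=C(S[C@@H]2CN[C@H](C(=O)Nc3cccc(C(=O)OCOC(=O)C(C)C)c3)C2)[C@H](C)[C@@H]2[C@@H]([C@@H](C)O)C(=O)N12` carries an ester at both ends; in an ADME assay on a cell-free system (plasma, Homo sapiens) for metabolic stability, read by LC-MS, with a stated time of 60 min, at 37 degrees C, tested at 50 uM (on this read-out lower numbers stand for a less stable compound and higher numbers for a more stable compound), compound 1 gives 8%, the lowest of the two numbers seen. Compound 2 `C[C@@H](O)[C@H]1C(=O)N2C(C(=O)OCOC(=O)C(C)(C)C)=C(S[C@@H]3CN[C@H](C(=O)Nc4cccc(C(=O)O)c4)C3)[C@H](C)[C@H]12`, which keeps an ester on the core and a free acid on the aryl ring, gives 45% in this assay, a number that stands well beyond the scatter from that of compound 1.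

Compound 3 `CC(C)C(=O)OCOC(=O)c1cccc(NC(=O)[C@@H]2C[C@H](SC3=C(C(=O)O)N4C(=O)[C@H]([C@@H](C)O)[C@H]4[C@H]3C)CN2)c1` is not yet measured. It differs from compound 1 in one place: hydrogen in place of ((isopropylcarbonyl)oxy)methyl on an oxygen next to a carbonyl group. The core carboxylic acid is thus freed while the aryl ester of compound 1 stays.

Within the data shown here, no step between measured compounds is known here, so the expectation rests on the two values alone. Compound 3 is expected to sit higher than compound 1, because compound 2, which likewise holds only one ester, gives 45%, and the expected step is a number 30 percentage points higher from compound 1 to compound 3 (beyond the scatter). Compound 3 is therefore estimated at 38%, with a range from 15% to 65%.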

Compound 3, percent of the compound remaining: 26%
For compound 3 the middle estimate is 12 percentage points above the measured one, and the stated range covers the measured number.
By their numbers in this assay, from the lowest: compound 1; then compound 3; then compound 2.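

In this assay, among these compounds, putting hydrogen in place of ((isopropylcarbonyl)oxy)methyl on an oxygen next to a carbonyl group gives a number 18 percentage points higher from compound 1 to compound 3 (beyond the scatter), the first change in a single place that can be read. It shows that this one group, taken alone, matters to the percent of compound remaining, since the step lies beyond the usual scatter even though the second ((isopropylcarbonyl)oxy)methyl ester of compound 1 stays in place in compound 3. Nothing at hand explains why the number moves, and the result alone does not identify what happens to either compound during the incubation.

The compounds shown leave open whether the same change at the second ester, made on its own from compound 1, would give a step of similar size, and whether the step at this oxygen reflects the ((isopropylcarbonyl)oxy)methyl group in particular. A ((tert-butylcarbonyl)oxy)methyl group, a plain ethyl ester or a primary amide in this place could tell how far the result depends on the group that leaves.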